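This account rests on a few compounds, and the source may have more. Where it says the series, first, only, none or still open, it means among the compounds named here.

The three measured compounds share one core and differ only in the group carried on an amine nitrogen. In a functional assay on HeLa cells (Homo sapiens) for inhibition, read by MTT assay, with a stated time of 48 h (a lower number here means a stronger inhibitor, a higher number a weaker inhibitor), compound 1 `CCOC(=O)C1=C(N/N=C(/Br)c2ccccc2)Nc2[nH]nc(C)c2C1c1ccc(N(C)C)cc1` gives 75700 nM and compound 2 `CCOC(=O)C1=C(N/C=N/c2ccccn2)Nc2[nH]nc(C)c2C1c1ccc(N(C)C)cc1` gives 29200 nM, the change between them being a 2.6-fold lower number from compound 1 to compound 2 (0.41 log units; beyond the scatter). For compound 3 `CCOC(=O)C1=C(N/N=C(/C(C)=O)C(=O)OCC)Nc2[nH]nc(C)c2C1c1ccc(N(C)C)cc1` this assay reports only a limit, > 100000 nM. Compound 3 thus stands at the weak end of what has been seen, resting at the limit of > 100000 nM in this assay, at which 1 of the 3 values shown sits. Compound 4 `CCOC(=O)C1=C(N/N=C(/Cl)c2ccc([N+](=O)[O-])cc2)Nc2[nH]nc(C)c2C1c1ccc(N(C)C)cc1` has not yet been measured. It differs from compound 3 in one place: a group of 12 heavy atoms (7 carbon, 2 nitrogen, 2 oxygen, 1 chlorine; one six-membered aromatic ring of carbon only) in place of a group of 10 heavy atoms (6 carbon, 1 nitrogen, 3 oxygen; no ring), on an amine nitrogen. The measured steps that bear on this change are an at least 1.3-fold higher number from compound 1 to compound 3 (0.12 log units; that floor lies within the scatter) and an at least 3.4-fold higher number from compound 2 to compound 3 (0.53 log units; beyond the scatter). Since the group entering in compound 4 resembles that of compound 1, whose value is 75700 nM, a step back toward a lower number is expected, of about an at least 1.4-fold lower number from compound 3 to compound 4 (0.15 log units; that floor lies within the scatter). Compound 4 is therefore expected to give roughly 70000 nM in this assay, within a range from 30000 nM to 160000 nM.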

Compound 4, half-maximal inhibitory concentration: 46200 nM
Compound 4: the middle estimate sits 1.5-fold (0.18 log units) above what was measured, and the stated range covers the measured number.
By their numbers in this assay, from the lowest: compounds 2, 4 and 1 (each within the scatter of the next, the first and the last beyond it). At a limit, above all of these: compound 3.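

Compound 4 shows that a second group with a six-membered aromatic ring of carbon only also gives a number in this assay, in place of the ringless group of compound 3 (an at least 2.1-fold lower number from compound 3 to compound 4 (0.33 log units; beyond the scatter)). It cannot be told apart from either earlier ring-bearing compound (a 1.6-fold lower number from compound 1 to compound 4 (0.21 log units; within the scatter); a 1.6-fold higher number from compound 2 to compound 4 (0.20 log units; within the scatter)), so the larger group with chlorine shows no separate gain or loss on this amine nitrogen. Going by these compounds alone, compound 3, the only ringless compound, is still held at a limit and not a number: the limit of > 100000 nM in this assay, at which 1 of the 4 values shown sits.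

Chlorine and the added nitrogen and oxygen atoms enter compound 4 together, so their separate shares stay unknown. From the compounds shown here alone, it also remains open how a ring carrying an amine or a carboxylic acid would read, or whether a ringless group such as a longer alkyl chain would also stay at a limit.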